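The source may report more compounds than this note shows. Statements on the series, on what has been measured and on what is new or still open speak of the compounds shown alone.

Compounds measured so far:
compound 1, `COC(=O)c1ccnc(O[C@@H]2CC[C@@H](C)N(C(=O)c3ccccc3-n3nccn3)C2)c1`, 310 nM in an assay on CHO-K1 cells for displacement of a labelled ligand from Orexin/Hypocretin receptor type 1 (Homo sapiens), read by radioligand binding; a lower number here means a stronger inhibitor, a higher number a weaker inhibitor;
compound 2, `Cc1cccnc1O[C@@H]1CC[C@@H](C)N(C(=O)c2ccccc2-n2nccn2)C1`, 4760 nM.

Compound 2 gives the highest of the two numbers in this assay; its nearest neighbour is compound 1, and the step of a 15-fold higher number from compound 1 to compound 2 (1.19 log units; beyond the scatter) puts the two well apart. Compound 3, `C[C@@H]1CC[C@@H](Oc2ccccn2)CN1C(=O)c1ccccc1-n1nccn1`, has not yet been measured. It differs from compound 2 by hydrogen in place of methyl on an aromatic carbon, so that the 3-methylpyridin-2-yl of compound 2 becomes a plain pyridin-2-yl.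

For the measured compounds named here, only one measured step exists, a 15-fold higher number from compound 1 to compound 2 (1.19 log units; beyond the scatter), and it concerns the exchange of a whole substituted pyridine for another; it does not tell how the methyl alone acts, since no pair of compounds differs by that group alone. The step from compound 2 to compound 3 is therefore estimated with little support: a modest move is expected, most likely toward a lower number, but the expectation a 1.9-fold lower number from compound 2 to compound 3 (0.28 log units; within the scatter) carries a wide range. Compound 3 is expected to give about 2500 nM, between 800 nM and 8000 nM.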

Compound 3, inhibition constant: 14000 nM
Estimate against measurement, compound 3: 5.6-fold (0.75 log units) below; measured number outside the range, above it.
By their numbers in this assay, from the lowest: compound 1; then compound 2; then compound 3.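

In this assay, for the compounds shown here, the methyl group can now be read on its own for the first time: a 2.9-fold higher number from compound 2 to compound 3 (0.47 log units; beyond the scatter) when hydrogen replaces methyl on the aromatic carbon ortho to a large group, so the plain pyridin-2-yl ranks below the 3-methylpyridin-2-yl as an inhibitor. Compound 3 also gives the unsubstituted reference that the earlier pair lacked, and the removal of methoxycarbonyl is a much larger step, a 45-fold higher number from compound 1 to compound 3 (1.65 log units; beyond the scatter), so both the 3-methylpyridin-2-yl and the 4-(methoxycarbonyl)pyridin-2-yl give lower numbers than the plain ring, each with its group on a different ring carbon. Nothing measured on these compounds accounts for either step.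

The compounds shown leave open whether the lower number at the methyl position is specific to methyl or would also appear with an ethyl group, a methoxy group or a chlorine atom on the same carbon. They also leave open whether the ester of compound 1 is itself needed, since a carboxylic acid, a primary amide or a simple methyl group on that carbon could separate the effect of the methoxycarbonyl group from that of any substituent there.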